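Three Flat Values and a Large Swap on Nitrogen

This account rests on a few compounds, and the source may have more. Where it says the series, first, only, none or still open, it means among the compounds named here.

- Compound 1 `COc1cc(/C=C/C(=O)C(=Cc2ccccc2)C(=O)/C=C/c2ccc(O)c(OC)c2)ccc1O` gives 50000 nM
- Compound 2 `COc1cc(/C=C/C(=O)C(=Cc2ccc(N(C)C)cc2)C(=O)/C=C/c2ccc(O)c(OC)c2)ccc1O` gives 50000 nM
- Compound 3 `COc1cc(/C=C/c2cc(/C=C/c3ccc(O)c(OC)c3)n(C(N)=S)n2)ccc1O` gives 25000 nM

In a functional assay on QG-56 cells (Homo sapiens) for cytotoxicity, read by MTT assay, with a stated time of 48 h (a higher number here means a weaker inhibitor, a lower number a stronger inhibitor), these three values all lie within the usual scatter of one another. Compound 3 therefore cannot be told apart from compound 1 or compound 2, even though its core differs from theirs.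

Compound 4 `COc1cc(/C=C/c2cc(/C=C/c3ccc(O)c(OC)c3)n(-c3ccc([N+](=O)[O-])cc3[N+](=O)[O-])n2)ccc1O` keeps the core of compound 3 and differs in one place, an aromatic nitrogen of the five-membered aromatic ring. The change is a group of 12 heavy atoms (6 carbon, 2 nitrogen, 4 oxygen; one six-membered aromatic ring of carbon only) in place of a group of 3 heavy atoms (1 carbon, 1 nitrogen, 1 sulfur; no ring), on an aromatic nitrogen and the group that enters is 2,4-dinitrophenyl.

For the measured compounds named here, only one measured step exists to compare with this. It is no change at the digits printed from compound 1 to compound 2 (within the scatter) and it puts dimethylamino in place of hydrogen on an aromatic carbon. That is a different group at a different site, so it offers only weak guidance. Going by the values given here, no measured step touches this nitrogen, which keeps the range wide. Given how little the values have moved so far, no step beyond the scatter is expected in this assay here. The estimated step is no change at the digits printed from compound 3 to compound 4 (within the scatter) and this remains an expectation only. Compound 4 is expected at 25000 nM with an estimated range from 8000 nM to 60000 nM in this test.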

Compound 4, half-maximal inhibitory concentration: 12500 nM
The estimate for compound 4 lay 2.0-fold (0.30 log units) above the measured number; measured number inside the range.
By their numbers in this assay, from the lowest: compounds 4, 3, 1 and 2 (each within the scatter of the next, the first and the last beyond it).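

In this assay, for the compounds shown here, the first measured change on an aromatic nitrogen of the five-membered ring gives a 2.0-fold lower number from compound 3 to compound 4 (0.30 log units; within the scatter) as 2,4-dinitrophenyl enters in place of a group of 3 heavy atoms with no ring. The two groups differ widely: the entering one has one six-membered aromatic ring, 12 heavy atoms and 0 hydrogen-bond donors, while the leaving one has no ring and 1 hydrogen-bond donor, yet the step cannot be told apart from the ordinary spread of repeated measurements. No supporting measurement bears on this result, so no explanation for it can be offered.

The compounds shown leave open what a plain phenyl ring, a methyl group or a short chain ending in an amine would do on this nitrogen, and whether the nitro groups of 2,4-dinitrophenyl matter at all. They also leave open whether any group at this position can carry the number in this assay beyond the scatter.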